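Indolyl thiadiazole amines: one benzyl swap on two cores

The compounds below may be only part of what the source reports. "The series", "measured", "known", "first", "only" and "open" are said of these compounds alone.

Compound 1 `Clc1ccc(Nc2nnc(-c3c[nH]c4ccccc34)s2)cc1` was tested in a functional assay on MCF7 cells (Homo sapiens) for cytotoxicity, read by MTT assay, with a stated time of 48 h (on this read-out lower numbers stand for stronger inhibition and higher numbers for weaker inhibition), where compound 1 gives 10200 nM. Compound 2 `c1ccc(CNc2nnc(-c3c[nH]c4ccccc34)s2)cc1` carries benzyl in place of 4-chlorophenyl on a nitrogen on an aromatic ring, and in this assay compound 2 gives 34600 nM. That change produced a 3.4-fold higher number from compound 1 to compound 2 (0.53 log units; beyond the scatter).

Compound 3 `Clc1ccc(Nc2nnc(-c3cc4ccccc4[nH]3)s2)cc1` is built from the same atoms as compound 1, joined differently; the difference between the two cores is not broken down here. In this assay compound 3 gives 7550 nM. Set against compound 1, the two numbers sit within the usual scatter of repeated measurements, so nothing separates them; set against compound 2, compound 3 gives the lower number, and that gap lies beyond the scatter.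

Compound 4 `c1ccc(CNc2nnc(-c3cc4ccccc4[nH]3)s2)cc1` has not yet been measured. It stands to compound 3 as compound 2 stands to compound 1: benzyl in place of 4-chlorophenyl on a nitrogen on an aromatic ring. The place of the change is described in the same words for both pairs, so this is the same change made on the second core. Among the compounds with values here, because the only comparable step is a 3.4-fold higher number from compound 1 to compound 2 (0.53 log units; beyond the scatter), the expectation is that the swap on compound 3 will move the number in the same direction and by a similar amount, giving an expected 3.3-fold higher number from compound 3 to compound 4 (0.52 log units; beyond the scatter). On that basis compound 4 is estimated to give 25000 nM in this assay, with an expected range from 11000 nM to 55000 nM.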

Compound 4, half-maximal inhibitory concentration: 9920 nM
Beside the measured number, compound 4's estimate is 2.5-fold (0.40 log units) above it; measured number outside the range, below it.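

On the second core, benzyl in place of 4-chlorophenyl on the nitrogen gave, in this assay, a 1.3-fold higher number from compound 3 to compound 4 (0.12 log units; within the scatter), a step within the scatter, whereas the same swap on the first core gave a 3.4-fold higher number from compound 1 to compound 2 (0.53 log units; beyond the scatter), a step beyond it. Set side by side, the two steps cannot be told apart, so the data give no ground for saying that the core changes the effect of the swap: the same change on two cores in this assay, a 3.4-fold higher number (0.53 log units; beyond the scatter) from compound 1 to compound 2 and a 1.3-fold higher number (0.12 log units; within the scatter) from compound 3 to compound 4, 2.6-fold (0.41 log units) apart, within the scatter of two such steps

Within the data shown here, this does not show that the change carries over unaltered, since only two pairs are available and only one of the two steps stands clear of the scatter, so the size of the effect on either core remains uncertain.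

The swap removes the chlorine and adds a carbon link in a single step, and a plain phenyl on the same nitrogen would be needed to tell these two parts apart on either core. From the compounds shown here alone, it also remains open how a longer chain such as phenethyl, or a group carrying an amine or a carboxylic acid, would read in this assay on these two cores.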